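Four Related Compounds and Hexokinase-2 Inhibition

The source may report more compounds than this note shows. Statements on the series, on what has been measured and on what is new or still open speak of the compounds shown alone.

Compound 2 `O=C(CI)NCCCCNc1ncnc2c1ncn2[C@@H]1O[C@H](COP(=O)(O)OP(=O)(O)OP(=O)(O)O)[C@@H](O)[C@H]1O` was tested in an assay on isolated protein for inhibition of hexokinase-2 (Rattus norvegicus), with a stated time of 6 h, tested at 10 mM (a lower number here means less inhibition, a higher number more inhibition at the concentration tested (going by the name of the read-out)), and gives 0%. Two relatives sit alongside it. Compound 1 `CN(CCCN(C)C(=O)CCCCNc1ncnc2c1ncn2[C@@H]1O[C@H](COP(=O)(O)OP(=O)(O)OP(=O)(O)O)[C@@H](O)[C@H]1O)C(=O)CCCCNC(=O)CI` gives 0% in this assay, and compound 3 `O=C(CI)NCCCCCC(=O)NCCCCNc1ncnc2c1ncn2[C@@H]1O[C@H](COP(=O)(O)OP(=O)(O)OP(=O)(O)O)[C@@H](O)[C@H]1O` gives 0%. Compound 2 therefore stands level with compounds 1 and 3 at the digits shown, the nearest being compound 1 and the furthest compound 3, and the one measured step, no change at the digits printed from compound 2 to compound 3 (within the scatter), lies within the scatter.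

Compound 4 `CC(=O)NCCCCCCCCNc1ncnc2c1ncn2[C@@H]1O[C@H](COP(=O)(O)OP(=O)(O)OP(=O)(O)O)[C@@H](O)[C@H]1O` has not yet been measured. It differs from compound 2 in a single place: 4-acetamidobutyl in place of ((iodomethyl)carbonyl)amino on a saturated chain carbon, four bonds along the chain from a nitrogen on an aromatic ring. Among the measured compounds shown here, the only measured step of a comparable kind is no change at the digits printed from compound 2 to compound 3 (within the scatter), which likewise grew the chain past the iodine-bearing group and left the read-out unchanged. Compound 1, carrying a still larger appendage, also gives 0%. With every measured compound at the same level, nothing in these data points to a shift in either direction.

The step of no change at the digits printed from compound 2 to compound 4 (within the scatter) is therefore expected to be none beyond the scatter. Compound 4 is estimated at 0% in this assay, with an expected range from -8% to 10%.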

Compound 4, a percentage reported as inhibition, at one concentration (the size of the read-out at that concentration, not a potency): -12%
Compound 4: middle estimate off by 12 percentage points, on the high side; measured number outside the range, below it.
By their numbers in this assay, from the lowest: compound 4; then compounds 1, 2 and 3 (each within the scatter of the next).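

In this assay, among the compounds shown here, the step of a number 12 percentage points lower from compound 2 to compound 4 (beyond the scatter) is the first one beyond the scatter, so the read-out at this place, on a saturated chain carbon, four bonds along the chain from a nitrogen on an aromatic ring, is not flat across every change made there. Compounds 1, 2 and 3 all carry the ((iodomethyl)carbonyl)amino group and sit level, and compound 4, the only one of the four without iodine, is the one that departs from them, with a reading of -12% that falls on the negative side of zero. Extending the chain with the iodine-bearing end kept gave no change at the digits printed from compound 2 to compound 3 (within the scatter), so added length with that end in place did not move the number, whereas the change to 4-acetamidobutyl, which replaces that end and also adds to the chain, did.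

The compounds shown leave open whether the lower number goes with the missing iodine or with the longer chain, which a plain acetamido group on the four-carbon chain of compound 2, or a free amine or carboxylic acid at the chain end, would help to separate. No measurement offered here accounts for the step.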